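Phenoxy versus benzyloxy at the aryl ether

The source may hold more compounds than are shown below. What is called first, only, known or untested is meant among the compounds shown, and "the series" means these compounds.

Working notes on the series. Compound 2 `Cc1ccccc1COc1ccc(N2CCC[C@H]2CC(=O)O)cc1` has no number in an assay on HEK293 cells for binding affinity to Free fatty acid receptor 1 (Homo sapiens), read by scintillation counting and radioligand binding, with a stated time of 1 h; on this read-out higher numbers stand for weaker inhibition and lower numbers for stronger inhibition: its entry is "not determined" (no result reported), so it cannot be placed on the scale, and compound 3 `Cc1ccccc1COc1ccc(N2CCC[C@H]2CC(=O)O)cc1C` likewise shows "not determined" (no result reported) in this assay. Going by the values given here, the only measured point is compound 1 `Cc1ccccc1Oc1ccc(N2C[C@@H](C(F)(F)F)C[C@H]2CC(=O)O)cc1`, which in this assay gives 35 nM.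

Compound 4 `Cc1ccccc1Oc1ccc(N2CCC[C@H]2CC(=O)O)cc1` is reached from compound 2 by 2-methylphenyl in place of 2-methylbenzyl on an oxygen on an aromatic ring. Among the compounds with values here, with no number for compound 2, no step in this assay can be computed for this pair, and the size and direction of the change remain open; the expectation rests on compound 1 alone. Compound 4 shares the 2-methylphenyl on the oxygen with compound 1, whose 35 nM in this assay therefore serves as the anchor, with some allowance for the other structural difference between the two. For compound 4 in this assay the estimated inhibition constant is 100 nM, expected to fall between 30 nM and 400 nM.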

Compound 4, inhibition constant: 4400 nM
Beside the measured number, compound 4's estimate is 44-fold (1.64 log units) below it; measured number outside the range, above it.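

With the 2-methylphenyl on the oxygen held fixed, hydrogen in place of trifluoromethyl on a saturated ring carbon gives a 130-fold higher number from compound 1 to compound 4 (2.10 log units; beyond the scatter) in this assay, a step beyond the scatter towards weaker inhibition, so the 2-methylphenyl ether alone does not carry the strong inhibition seen for compound 1, and the substituent on that ring carbon matters greatly in this pair. The change from 2-methylbenzyl to 2-methylphenyl still cannot be read, since compound 2 and compound 3 have no number, and the steps that would involve them remain unavailable. Nothing shown here accounts for the size of this step.

Open, as far as these compounds go, is whether a smaller group on that saturated ring carbon, such as a fluorine or a nitrile, would restore any of the lost strength. Also open, from the compounds shown here alone, is whether trifluoromethyl there would act to the same extent with 2-methylbenzyl on the oxygen.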